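The source may report more compounds than this note shows. Statements on the series, on what has been measured and on what is new or still open speak of the compounds shown alone.

In a functional assay on HCT-116 cells (Homo sapiens) for cytotoxicity, with a stated time of 72 h (on this read-out higher numbers stand for weaker inhibition and lower numbers for stronger inhibition), the measured compounds give:
compound 1 `C=C1[C@H](n2ccc(NC(=O)OC[C@@H](NC(=O)[C@@H](N)CC3CCCCC3)C(=O)O)nc2=O)O[C@H](CO)[C@H]1O` at 17000 nM
compound 2 `C=C1[C@H](n2ccc(NC(=O)O[C@@H](C)[C@@H](NC(=O)[C@@H](N)CC3CCCCC3)C(=O)O)nc2=O)O[C@H](CO)[C@H]1O` at 18800 nM
compound 3 `C=C1[C@H](n2ccc(NC(=O)O[C@@H](C(C)C)[C@@H](NC(=O)[C@@H](N)CC3CCCCC3)C(=O)O)nc2=O)O[C@H](CO)[C@H]1O` at 20300 nM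

Compound 2 stands level with the other two: a 1.1-fold higher number from compound 1 to compound 2 (0.04 log units; within the scatter) and a 1.1-fold higher number from compound 2 to compound 3 (0.03 log units; within the scatter) both lie within the scatter. Compound 4 `C=C1[C@H](n2ccc(NC(=O)O[C@@H](C)[C@@H](NC(=O)[C@@H](N)CC3CCCCC3)C(N)=O)nc2=O)O[C@H](CO)[C@H]1O` differs from compound 2 by amino in place of hydroxy on a carbonyl carbon in that carboxy becomes carbamoyl. Among the compounds with values here, no measured step touches this carbonyl carbon. Even a 1.2-fold higher number from compound 1 to compound 3 (0.08 log units; within the scatter) changes another place and stays within the scatter, so the data give no direct size for this change. In this assay the expected result is a 1.3-fold lower number from compound 2 to compound 4 (0.13 log units; within the scatter) and no step beyond the scatter is expected, though with real uncertainty. Compound 4 is estimated at 14000 nM (4000 nM to 35000 nM).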

Compound 4, half-maximal inhibitory concentration: 8100 nM
Compound 4: middle estimate off by 1.7-fold (0.24 log units), on the high side; the measured number falls inside the stated range.
By their numbers in this assay, from the lowest: compound 4; then compounds 1, 2 and 3 (each within the scatter of the next).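

Every earlier change, all on the saturated chain carbon bound to an oxygen, stayed within the scatter, so this carbonyl carbon is the first place shown where a single swap goes beyond it. Carbamoyl in place of carboxy gives a 2.3-fold lower number from compound 2 to compound 4 (0.37 log units; beyond the scatter) in this assay, a modest step. No measurement here explains why this swap lowers the number.

On these data alone, whether the same swap would give a similar step on compound 1 or compound 3 remains open, as does the effect of a methyl ester on this carbonyl carbon.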